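Ethynyl in place of phenyl on the shared core

The source may report more compounds than this note shows. Statements on the series, on what has been measured and on what is new or still open speak of the compounds shown alone.

In an ADME assay on BJ cells (Homo sapiens), read by MTT assay, with a stated time of 72 h (on this read-out higher numbers stand for weaker inhibition and lower numbers for stronger inhibition), compound 1 `CSc1ncnc2c1c(-c1cccs1)cn2[C@@H]1O[C@H](CO)[C@@H](O)[C@H]1O` gives 96900 nM. Compound 2 `CSc1ncnc2c1c(-c1ccccc1)cn2[C@@H]1O[C@H](CO)[C@@H](O)[C@H]1O` is recorded in this assay as > 100000 nM, which is a limit of the assay and not a number. Compound 2 therefore has no exact place in the series and stands only at the limit of > 100000 nM in this assay, at which 1 of the 2 values shown sits.

Compound 3 `C#Cc1cn([C@@H]2O[C@H](CO)[C@@H](O)[C@H]2O)c2ncnc(SC)c12` carries ethynyl in place of phenyl on an aromatic carbon.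

For the measured compounds named here, one measured step bears on this change: an at least 1.0-fold higher number from compound 1 to compound 2 (0.01 log units; that floor lies within the scatter), with phenyl in place of thiophen-2-yl on an aromatic carbon. Going by the values given here, that step exchanges one ring for another, and no measured step covers a group without a ring, so the size of the new step is poorly constrained. With compound 1 at 96900 nM, the measured values show no strong inhibition, so compound 3 is expected to remain weak, with some room for a lower number in this assay. The expected step is an at least 2.5-fold lower number from compound 2 to compound 3 (0.39 log units; beyond the scatter), and it could prove smaller if compound 3 also reaches the limit. For compound 3 the estimate is 40000 nM, with an expected range of 5000 nM to 100000 nM.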

Compound 3, half-maximal inhibitory concentration: 68600 nM
Compound 3: middle estimate off by 1.7-fold (0.23 log units), on the low side, and the stated range covers the measured number.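

In this assay, a group without a ring on this aromatic carbon leaves the number within the scatter of the thiophen-2-yl compound: a 1.4-fold lower number from compound 1 to compound 3 (0.15 log units; within the scatter). Against the phenyl compound the reading gives only a floor, and that floor does not separate the two: an at least 1.4-fold lower number from compound 2 to compound 3 (0.16 log units; that floor lies within the scatter). From the compounds shown here alone, compound 2 stands at a limit of the assay and not at a number, so the true size of that step stays unknown: the limit of > 100000 nM in this assay, at which 1 of the 3 values shown sits.

The three compounds therefore show no step beyond the scatter at this position, even though ethynyl brings 2 heavy atoms where phenyl brings 6, and they do not tell whether any group placed here would give a clearly stronger inhibition in this assay. An amine, a carboxylic acid or a longer chain on this aromatic carbon would test that question with groups unlike the two rings and the triple bond shown, and since the rest of the shared core is the same in all three compounds, the effect of a change anywhere else on it remains open.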